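3-Bromophenyl in place of 4-bromophenyl: estimating compound 4

A few compounds are considered here, and "the series" means these few. Any claim that something is new, unique, unknown or untested is made for them only; others in the source may bear on it.

Of the compounds shown here, three sharing one core have been measured in an ADME assay on HEK293 cells (Homo sapiens) for cytotoxicity, read by MTT assay, with a stated time of 72 h; a lower number here means a stronger inhibitor, a higher number a weaker inhibitor. In that test, compound 1 (`O=C(CN1CCN(C(=O)c2ccc(Br)cc2)CC1)N1CCN(CCCc2c[nH]c3ccccc23)CC1`) gives 71900 nM, compound 2 (`O=C(CN1CCN(C(=O)c2ccc(Cl)cc2)CC1)N1CCN(CCCc2c[nH]c3ccc(F)cc23)CC1`) gives 44500 nM and compound 3 (`O=C(CN1CCN(C(=O)c2ccc(Br)cc2)CC1)N1CCN(CCCc2c[nH]c3ccc(F)cc23)CC1`) gives 60500 nM. Compound 3 lies within the scatter of both of the others, so these numbers do not set it apart.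

Compound 4 (`O=C(CN1CCN(C(=O)c2cccc(Br)c2)CC1)N1CCN(CCCc2c[nH]c3ccc(F)cc23)CC1`) has not yet been measured and has the same atoms as compound 3, joined differently: 3-bromophenyl in place of 4-bromophenyl on a carbonyl carbon. It carries 3-bromophenyl in place of 4-bromophenyl on a carbonyl carbon.

Going by the values given here, no measured pair shows this change directly, so the evidence is only indirect. Fluoro in place of hydrogen on an aromatic carbon gives a 1.2-fold lower number from compound 1 to compound 3 (0.07 log units; within the scatter). Bromo in place of chloro on an aromatic carbon, the one measured change within this phenyl group, gives a 1.4-fold higher number from compound 2 to compound 3 (0.13 log units; within the scatter). Both steps stay within the scatter, so no step beyond the scatter, in either direction, is expected in this assay. The estimated change is a 1.0-fold lower number from compound 3 to compound 4 (0.02 log units; within the scatter), which is expected to stay within the scatter. For compound 4 the estimated value is 58000 nM, with an expected range from 35000 nM to 100000 nM.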

Compound 4, half-maximal inhibitory concentration: 40600 nM
For compound 4 the middle estimate is 1.4-fold (0.15 log units) above the measured one; the range from low to high includes it.
By their numbers in this assay, from the lowest: compounds 4, 2, 3 and 1 (each within the scatter of the next).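

In this assay, the change from 4-bromophenyl to 3-bromophenyl on a carbonyl carbon can now be read directly: it gives a 1.5-fold lower number from compound 3 to compound 4 (0.17 log units; within the scatter). The earlier compounds shown here showed only a swap of halogen on this phenyl group, whereas this step shows that changing where the bromine sits also leaves the two compounds within the scatter of each other, at least with the fluoro group present on the rest of the structure. Replacing 4-chlorophenyl with 3-bromophenyl, which changes both the halogen and its place, gives a 1.1-fold lower number from compound 2 to compound 4 (0.04 log units; within the scatter), so even this combined change does not separate the two compounds, and no measurement available here bears on what lies behind these small steps.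

All the compounds shown carry a bromine or chlorine on this phenyl group, so it remains open whether a methoxy group, an amine or a carboxylic acid there would give a step beyond the scatter. As far as these compounds go, it is also open whether 3-bromophenyl would behave in the same way on the core of compound 1, which has hydrogen in place of the fluoro group, or alongside a longer chain.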